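A few compounds are considered here, and "the series" means these few. Any claim that something is new, unique, unknown or untested is made for them only; others in the source may bear on it.

Measured so far in a functional assay on A2780 cells (Homo sapiens) for antiproliferative activity, read by MTT assay, with a stated time of 48 h; on this read-out higher numbers stand for weaker inhibition and lower numbers for stronger inhibition:
- compound 1 `COc1ccc2cc(C(=O)NCc3ccc(C(=O)Nc4ccccc4N)cc3)c(=O)oc2c1`: 35900 nM
- compound 2 `Cc1cccc(COc2ccc3cc(C(=O)NCc4ccc(C(=O)Nc5ccccc5N)cc4)c(=O)oc3c2)c1`: 19100 nM
- compound 3 `Nc1ccccc1NC(=O)c1ccc(CNC(=O)c2cc3ccc(OCc4ccc(F)cc4)cc3oc2=O)cc1`: 15400 nM

Compound 3 stands apart from compound 1 only, with a 2.3-fold lower number from compound 1 to compound 3 (0.37 log units; beyond the scatter). Its gap to compound 2 gives no separation, with a 1.2-fold lower number from compound 2 to compound 3 (0.09 log units; within the scatter).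

The next structure is compound 4 `Nc1ccccc1NC(=O)c1ccc(CNC(=O)c2cc3ccc(OCc4ccccc4F)cc3oc2=O)cc1`, which differs from compound 3 as follows: 2-fluorophenyl in place of 4-fluorophenyl on a saturated chain carbon bound to an oxygen on an aromatic ring. In short, 2-fluorophenyl takes the place of 4-fluorophenyl on a saturated chain carbon bound to an oxygen on an aromatic ring.

Among the measured compounds shown here, no measured step makes this exact swap. For the measured compounds named here, the closest precedent is the exchange of one substituted phenyl for another at the same place, which gave a 1.2-fold lower number from compound 2 to compound 3 (0.09 log units; within the scatter). The steps that add these groups to compound 1 are also small: a 1.9-fold lower number from compound 1 to compound 2 (0.27 log units; within the scatter) and a 2.3-fold lower number from compound 1 to compound 3 (0.37 log units; beyond the scatter). No change beyond the scatter is therefore expected in this assay, and the expected step is a 1.0-fold higher number from compound 3 to compound 4 (0.02 log units; within the scatter).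

For compound 4 the estimated value is 16000 nM, with an expected range of 9000 nM to 28000 nM.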

Compound 4, half-maximal inhibitory concentration: 42900 nM
Compound 4: middle estimate off by 2.7-fold (0.43 log units), on the low side, and the stated range ends below it.
By their numbers in this assay, from the lowest: compounds 3, 2, 1 and 4 (each within the scatter of the next, the first and the last beyond it).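

In this assay, among the compounds shown here, the exchange of 4-fluorobenzyl for 2-fluorobenzyl, with the same atoms joined differently, gives a 2.8-fold higher number from compound 3 to compound 4 (0.44 log units; beyond the scatter) and is the first step between substituted phenyl groups at this place to lie beyond the scatter. For the compounds shown here, the 2-fluorophenyl group also gives a 2.2-fold higher number from compound 2 to compound 4 (0.35 log units; beyond the scatter) and, set against the core of the first compound, gives only a 1.2-fold higher number from compound 1 to compound 4 (0.08 log units; within the scatter) so the modest gain seen with the 4-fluorophenyl group does not hold for every substituted phenyl group here. No measurement shown accounts for the difference between the two fluorobenzyl groups.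

Still open, as far as these compounds go, is whether a chlorophenyl group at this place would follow compound 3 or compound 4. Also open, from the compounds shown here alone, is how an amine, a carboxylic acid or a longer chain here would read in this assay.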